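The compounds below may be only part of what the source reports. "The series", "measured", "known", "first", "only" and "open" are said of these compounds alone.

Compound 1 `CC(O)(CS(=O)(=O)c1ccc(Cl)cc1)c1nc(-c2ccc(Cl)cc2)no1` and compound 2 `CC(O)(CS(=O)(=O)c1ccccc1)c1nc(-c2ccc(Cl)cc2)no1` differ in one place, yet the step that the two limits leave unreadable from compound 1 to compound 2 cannot be read. In a functional assay on DU-145 cells (Homo sapiens) for cytotoxicity, read by MTT assay (on this read-out higher numbers stand for weaker inhibition and lower numbers for stronger inhibition), compound 1 gives > 100000 nM, which is a limit of the assay. In this assay compound 2 gives > 100000 nM, again a limit. Among the compounds with values here, compound 3 `CC(O)(CS(=O)(=O)c1ccc(Br)cc1)c1nc(-c2ccc(F)c(Cl)c2)no1` is the only compound with a number: in this assay compound 3 gives 75000 nM, while the other two sit at the limit of > 100000 nM in this assay, at which 2 of the 3 values shown sit. Compound 4 `CC(O)(CS(=O)(=O)c1ccc(Br)cc1)c1nc(-c2ccc(Cl)cc2)no1` has not yet been measured; it differs from compound 3 by 4-chlorophenyl in place of 3-chloro-4-fluorophenyl on an aromatic carbon. Within the data shown here, no measured step bears on this change, and the single recorded step is unreadable, so the expected step of a 1.3-fold higher number from compound 3 to compound 4 (0.12 log units; within the scatter) is small, with a fair chance of another limit. Compound 4 is estimated at 100000 nM, between 40000 nM and 300000 nM.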

Compound 4, half-maximal inhibitory concentration: > 100000 nM
Compound 4: only a limit was reported (the forecaster's own chance of this, stated with the estimate: 60%); the middle value lies on the limit itself.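

From the compounds shown here alone, with 4-chlorophenyl in place of 3-chloro-4-fluorophenyl on the carbon between two ring nitrogen atoms, this assay shows an at least 1.3-fold higher number from compound 3 to compound 4 (0.12 log units; that floor lies within the scatter); this is only a floor, so the true size of the change at this position remains unknown. The steps from compound 2 and from compound 1 to compound 4 cannot be read, with limits at both ends. Compound 3 remains the only compound with a number, and the others share one limit: the limit of > 100000 nM in this assay, at which 3 of the 4 values shown sit.

Going by these compounds, what an amine or a carboxylic acid at this position in place of the 4-chlorophenyl would give stays open.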